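Shortening the alkyl chain on the core of compound 1

A few compounds are considered here, and "the series" means these few. Any claim that something is new, unique, unknown or untested is made for them only; others in the source may bear on it.

Within the data shown here, compound 1, whose structure is `CCc1cccc2nc(N3CCN(C)CC3)oc12`, stands at the lower end of the two numbers so far in a functional assay on ileum (strain Hartley) for agonist activity at 5-hydroxytryptamine receptor 3A (Cavia porcellus); on this read-out lower numbers stand for lower potency and higher numbers for higher potency (the scale is a negative logarithm): compound 1 gives 5.48. Among the measured compounds shown here, its only measured neighbour is compound 2, `CCc1cc(C)cc2nc(N3CCN(C)CC3)oc12`, which in this assay gives 6.46; the step of a number 0.98 log units higher from compound 1 to compound 2 (beyond the scatter) comes from a methyl in place of hydrogen on an aromatic carbon. The unmeasured compound 3, `Cc1cccc2nc(N3CCN(C)CC3)oc12`, differs from compound 1 in another place: hydrogen in place of methyl on a saturated chain carbon bound to an aromatic carbon. Read one bond further out, the change is ethyl to methyl. For the measured compounds named here, no measured step touches this saturated chain, since the one step on record alters the aromatic ring instead, so the size of the effect of trimming the chain is unknown from these data. Compound 3 is therefore expected to stay close to compound 1, with a step of a number 0.18 log units lower from compound 1 to compound 3 (within the scatter) that may not rise beyond the scatter. The estimate for compound 3 in this assay is 5.3, within a range from 4.7 to 5.9.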

Compound 3, negative logarithm of the half-maximal effective concentration: 5.48
Beside the measured number, compound 3's estimate is 0.18 log units below it, and the stated range covers the measured number.
By their numbers in this assay, from the lowest: compounds 1 and 3 (each within the scatter of the next); then compound 2.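

In this assay, hydrogen in place of methyl on a saturated chain carbon bound to an aromatic carbon gives no change at the digits printed from compound 1 to compound 3 (within the scatter), so on this read-out ethyl and methyl at this place cannot be told apart. Among these compounds, until now the only step on record lay on the aromatic ring, where a methyl in place of hydrogen gave a number 0.98 log units higher from compound 1 to compound 2 (beyond the scatter); the saturated chain now has a step of its own, and it stays within the scatter. Nothing on hand offers a reason for this result.

From the compounds shown here alone, it remains open whether a longer chain such as propyl or butyl, a branched isopropyl group, or a methoxy group at this place would leave the number as flat as the change from ethyl to methyl did, and whether removing the chain entirely would do the same. Also open, going by these compounds, is whether adding the aromatic methyl of compound 2 to compound 3 would bring the same gain as it did on compound 1, with its ethyl chain.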